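This account rests on a few compounds, and the source may have more. Where it says the series, first, only, none or still open, it means among the compounds named here.

Of the compounds shown here, two with a shared core have been measured in an ADME assay on microsomes from liver (Mus musculus) for metabolic stability; a higher number here means that the compound lasts longer, a lower number that the compound disappears faster. Compound 1 `NS(=O)(=O)CC(=O)NCCSc1nonc1/C(=N/O)Nc1cccc(Cl)c1` gives 1.26 h, and compound 2 `NS(=O)(=O)CC(=O)NCCSc1nonc1/C(=N/O)Nc1ccc(F)c(C(F)F)c1` gives 1.07 h. For the measured compounds named here, the one step between them, a 1.2-fold lower number from compound 1 to compound 2 (0.07 log units; within the scatter), shows that swapping the aromatic ring on the amine nitrogen left the half-life essentially unchanged. Compound 2 therefore stands at the lower of the two numbers, but only by an amount that repeated measurements would not reliably separate.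

Compound 3 `N#Cc1cccc(N/C(=N\O)c2nonc2SCCNC(=O)CS(N)(=O)=O)c1` keeps the whole core and again alters only the aromatic ring on the amine nitrogen: 3-cyanophenyl in place of 3-(difluoromethyl)-4-fluorophenyl on an amine nitrogen. Going by the values given here, the single step that bears on such a change, a 1.2-fold lower number from compound 1 to compound 2 (0.07 log units; within the scatter), was within the scatter, so no shift beyond the scatter is expected here either, and the estimated step is a 1.0-fold higher number from compound 2 to compound 3 (0.01 log units; within the scatter). Compound 3 is thus expected to give about 1.1 h in this assay, with a likely range from 0.6 h to 2.2 h.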

Compound 3, half-life: > 3 h
Compound 3: only a limit was reported; the forecaster's own chance of this, stated with the estimate: 5%; middle value at least 2.7-fold (0.43 log units) away from the limit.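

The aromatic ring on the amine nitrogen turns out to matter for how long these compounds last, which the first pair could not show, since its change stayed within the scatter. Putting 3-cyanophenyl in place of 3-(difluoromethyl)-4-fluorophenyl gives an at least 2.8-fold higher number from compound 2 to compound 3 (0.44 log units; beyond the scatter), and the smaller change of cyano in place of chloro on an aromatic carbon gives an at least 2.3-fold higher number from compound 1 to compound 3 (0.37 log units; beyond the scatter), so swapping that one group on the ring is enough to move the result beyond the scatter. The figure for compound 3 in this assay is a limit and not a measured number: the limit of > 3 h in this assay, at which 1 of the 3 values shown sits.

Going by these compounds, how far the true half-life of compound 3 lies past that limit stays open. Also open, on these data alone, is whether an amine or a carboxylic acid in place of the nitrile on the same ring would last as long.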